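The source may report more compounds than this note shows. Statements on the series, on what has been measured and on what is new or still open speak of the compounds shown alone.

Measured compounds in a functional assay on HT-29 cells (Homo sapiens) for antiproliferative activity, read by sulforhodamine B assay, with a stated time of 48 h; a higher number here means a weaker inhibitor, a lower number a stronger inhibitor:
compound 1 `CC(=O)Nc1ccc(S(=O)(=O)Oc2ccccc2I)cc1` gives 23000 nM
compound 2 `CCC(=O)Nc1ccc(S(=O)(=O)Oc2ccccc2I)cc1` gives 11000 nM
compound 3 `CC(C)C(=O)Nc1ccc(S(=O)(=O)Oc2ccccc2C(C)C)cc1` gives 14000 nM

Compound 1 and compound 2 share a core and differ in one place: methyl in place of hydrogen on a saturated chain carbon bound to a carbonyl carbon. That change gave a 2.1-fold lower number from compound 1 to compound 2 (0.32 log units; beyond the scatter). Compound 3 carries a different core; the difference between its core and that of compound 1 is not broken down here. In this assay compound 3 and compound 2 sit within the usual scatter of each other, as do compound 3 and compound 1.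

Compound 4 `CC(C)c1ccccc1OS(=O)(=O)c1ccc(NC(=O)C(C)(C)C)cc1` has not yet been measured. It differs from compound 3 in one place: methyl in place of hydrogen on a saturated chain carbon bound to a carbonyl carbon and two saturated chain carbons. For the measured compounds named here, this is the same kind of change as the one from compound 1 to compound 2, but not the same change: in compound 3 the saturated chain carbon that takes the methyl is bound to a carbonyl carbon and two saturated chain carbons, whereas in compound 1 it is bound to a carbonyl carbon only. The expectation for compound 4 rests on that single earlier step, made on another core. Compound 4 is expected to show a step of a 1.6-fold lower number from compound 3 to compound 4 (0.19 log units; within the scatter), of the same order as a 2.1-fold lower number from compound 1 to compound 2 (0.32 log units; beyond the scatter). Compound 4 is therefore estimated at 9000 nM, with a range from 4000 nM to 25000 nM.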

Compound 4, half-maximal inhibitory concentration: 15000 nM
The estimate for compound 4 lay 1.7-fold (0.22 log units) below the measured number; the range from low to high includes it.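

In this assay, the methyl that turns isopropyl into tert-butyl gave a 1.1-fold higher number from compound 3 to compound 4 (0.03 log units; within the scatter), a step within the scatter. Set beside the earlier step, the two cannot be told apart: the same change on two cores in this assay, a 2.1-fold lower number (0.32 log units; beyond the scatter) from compound 1 to compound 2 and a 1.1-fold higher number (0.03 log units; within the scatter) from compound 3 to compound 4, 2.2-fold (0.35 log units) apart, within the scatter of two such steps. This gives no ground for calling the change different on the two cores, but it does not show that the change carries over intact: each core offers a single pair, only the earlier step lies beyond the scatter, and the carbon that takes the methyl is bound differently in the two pairs.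

The compounds shown leave open how isopropylcarbonyl and (tert-butyl)carbonyl would read on the core of compound 1, which would set this change and the earlier one on a single core. They also leave open what a longer chain, an amine or a carboxylic acid in place of the tert-butyl would give in this assay.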